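Fluoro to Chloro: Expected Cytotoxicity of Compound 4

The source may report more compounds than this note shows. Statements on the series, on what has been measured and on what is new or still open speak of the compounds shown alone.

Measured so far in an ADME assay on NIH3T3 cells (Mus musculus) for cytotoxicity, read by MTT assay, with a stated time of 24 h; on this read-out higher numbers stand for weaker inhibition and lower numbers for stronger inhibition:
compound 1 `Cn1nnnc1SCC(=O)N/N=c1/scc(-c2ccc(F)cc2)n1-c1ccccc1` gives 113 ug/mL
compound 2 `O=C(CSc1nnnn1-c1ccccc1)N/N=c1/scc(-c2ccc(F)cc2)n1-c1ccccc1` gives 207 ug/mL
compound 3 `Cn1cnnc1SCC(=O)N/N=c1/scc(-c2ccc(F)cc2)n1-c1ccccc1` gives 65 ug/mL

Compound 1 stands second highest of the three numbers, and both neighbours sit close to it: a 1.7-fold lower number from compound 1 to compound 3 (0.24 log units; within the scatter), and a 1.8-fold higher number from compound 1 to compound 2 (0.26 log units; within the scatter). Among the compounds with values here, only the step between the other two reaches beyond the scatter: a 3.2-fold lower number from compound 2 to compound 3 (0.50 log units; beyond the scatter). All three measured steps change the group attached to the sulfur, and none of them touches the fluoro-bearing ring.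

Compound 4 `Cn1nnnc1SCC(=O)N/N=c1/scc(-c2ccc(Cl)cc2)n1-c1ccccc1` differs from compound 1 by chloro in place of fluoro on an aromatic carbon. Within the data shown here, no measured step bears on this change, so there is nothing in the data to suggest a shift beyond the scatter in this assay, in either direction. Compound 4 is therefore expected to give about 100 ug/mL, most likely between 50 ug/mL and 200 ug/mL. The expected step is a 1.1-fold lower number from compound 1 to compound 4 (0.05 log units; within the scatter).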

Compound 4, half-maximal inhibitory concentration: 40 ug/mL
Estimate against measurement, compound 4: 2.5-fold (0.40 log units) above; the whole stated range lies above it.
By their numbers in this assay, from the lowest: compounds 4, 3, 1 and 2 (each within the scatter of the next, the first and the last beyond it).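

Changing the ring substituent, with chloro in place of fluoro, gives in this assay a 2.8-fold lower number from compound 1 to compound 4 (0.45 log units; beyond the scatter). Within the data shown here, the earlier steps all changed the group on the sulfur, so this is the first sign that the 4-fluorophenyl end of the molecule also affects the read-out: exchanging one atom there moves the number modestly, but beyond the scatter. Nothing available explains this shift.

As far as these compounds go, it remains open whether the shift is specific to chloro or would also appear with other groups at this place on the ring, such as bromo, methyl or an amine. From the compounds shown here alone, it is also open whether the same exchange would give a similar step in compound 2 or compound 3, which carry different groups on the sulfur.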